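Chloro on the pyridine side of a sulfonylcarbamoyl series

The source may hold more compounds than are shown below. What is called first, only, known or untested is meant among the compounds shown, and "the series" means these compounds.

Measured so far in a functional assay on HT-29 cells (Homo sapiens) for antiproliferative activity, read by MTT assay, with a stated time of 24 h, tested at 10 uM; a higher number here means more inhibition at the concentration tested (going by the name of the read-out), a lower number less inhibition:
compound 1 `O=C(NS(=O)(=O)c1ccccc1)n1ccc2cccnc21` — 23.6%
compound 2 `O=C(NS(=O)(=O)c1ccc2ccccc2c1)n1ccc2cccnc21` — 16.2%
compound 3 `O=C(NS(=O)(=O)c1ccccc1)n1ccc2c(Cl)ccnc21` — 47.6%

Compound 3 differs from compound 1 by chloro in place of hydrogen on an aromatic carbon, and this gave a number 24 percentage points higher from compound 1 to compound 3 (beyond the scatter). The difference between the cores of compound 1 and compound 2 is not broken down here; the values of compound 1 and compound 2 lie within the scatter of each other.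

Compound 4 `O=C(NS(=O)(=O)c1ccc2ccccc2c1)n1ccc2c(Cl)ccnc21` is not yet measured. It differs from compound 2 by chloro in place of hydrogen on an aromatic carbon, the same change as from compound 1 to compound 3. The step from compound 2 to compound 4 is expected to be about a number 21.8 percentage points higher from compound 2 to compound 4 (beyond the scatter), resting on the single earlier case, compound 1 to compound 3, with a number 24 percentage points higher from compound 1 to compound 3 (beyond the scatter); one example is a thin basis, so the range is kept wide. Compound 4 is estimated at 38%, between 22% and 54%.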

Compound 4, a percentage reported as inhibition, at one concentration (the size of the read-out at that concentration, not a potency): 58.2%
The estimate for compound 4 lay 20.2 percentage points below the measured number; measured number outside the range, above it.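

In this assay, chloro in place of hydrogen on an aromatic carbon gave a number 42 percentage points higher from compound 2 to compound 4 (beyond the scatter), so the number rose on both cores. The direction carried over from one core to the other, but the size did not: the same change on two cores in this assay, a number 24 percentage points higher (beyond the scatter) from compound 1 to compound 3 and a number 42 percentage points higher (beyond the scatter) from compound 2 to compound 4, 18 percentage points apart, beyond the scatter of two such steps

The gain therefore cannot be treated as a fixed increment to add to any core in this series, and two cores do not show how large it would be on a third or why the two steps differ.

Still open, going by these compounds, is whether fluoro, methoxy or an amine in the same place, opposite the ring nitrogen, would behave as chloro does. Also open, on these data alone, is whether the difference between the steps would hold as a difference in potency, as each number is a reading at a single concentration.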